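The source may hold more compounds than are shown below. What is called first, only, known or untested is meant among the compounds shown, and "the series" means these compounds.

Among the compounds with values here, only two compounds have been measured so far. In a functional assay on OVCAR-4 cells (Homo sapiens) for inhibition, read by sulforhodamine B assay, with a stated time of 48 h (a higher number here means a weaker inhibitor of growth, a lower number a stronger inhibitor of growth), compound 1 (`CN(C)/C=C/C(=O)c1nn(-c2ccccc2)c(-c2ccccc2)c1C#N`) gives 63800 nM and compound 2 (`Cc1nnc(-c2nn(-c3ccccc3)c(-c3ccccc3)c2C#N)c2cn(-c3ccccc3)nc12`) gives 56400 nM. Compound 2 has the lower of the two numbers, but the gap lies within the usual scatter of repeated measurements, so the two cannot be told apart. These two compounds also differ in more than one place, so they say nothing about the effect of any single change.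

The next compound is compound 3 (`N#Cc1c(-c2nnc(O)c3nn(-c4ccccc4)cc23)nn(-c2ccccc2)c1-c1ccccc1`). It keeps the structure of compound 2 except at one spot, where hydroxy stands in place of methyl on an aromatic carbon (hydroxy in place of methyl on an aromatic carbon). Within the data shown here, no measured pair shows what this swap does in this assay, so the expectation starts from compound 2 at 56400 nM and assumes little movement. The expected change is a 1.1-fold lower number from compound 2 to compound 3 (0.05 log units; within the scatter), which is no step beyond the scatter and has no firm direction. For compound 3 the estimated value is 50000 nM, with an expected range from 20000 nM to 100000 nM.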

Compound 3, concentration for 50% growth inhibition: 26400 nM
The estimate for compound 3 lay 1.9-fold (0.28 log units) above the measured number, and the stated range covers the measured number.
By their numbers in this assay, from the lowest: compound 3; then compounds 2 and 1 (each within the scatter of the next).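

Within the data shown here, replacing methyl with hydroxy on this aromatic carbon, next to the ring nitrogen, gives a 2.1-fold lower number from compound 2 to compound 3 (0.33 log units; beyond the scatter) in this assay and is the first single change here to move the number beyond the usual scatter. Among these compounds, the step is modest, but it shows that this position is not indifferent to what sits on it, even though only one heavy atom changes, a carbon giving way to an oxygen, and the hydroxy brings a hydrogen-bond donor and a hydrogen-bond acceptor that the methyl lacks. No measurement at hand bears on why the number moved.

From the compounds shown here alone, with only methyl and hydroxy seen at this spot, it remains open whether the lower number is particular to hydroxy or would also appear with other groups there, such as an amine, a methoxy or a chlorine atom. Going by these compounds, it is also open whether the same swap would give a similar step on a different core, or whether larger groups at this position would push the number further down or back up.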